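Swapping a Benzothiazole for Nitro: Cytotoxicity in THP-1 Cells

This account rests on a few compounds, and the source may have more. Where it says the series, first, only, none or still open, it means among the compounds named here.

Of the compounds shown here, three built on one shared core have been measured, and a fourth awaits its value. Compound 3 `CC1(C)OC(=O)C(=CNc2cccc(-c3nc4ccccc4s3)c2)C(=O)O1` carries a 1,3-benzothiazol-2-yl group, and in an ADME assay on THP-1 cells (Homo sapiens) for cytotoxicity, read by flow cytometry and propidium iodide staining, with a stated time of 72 h (on this read-out lower numbers stand for stronger inhibition and higher numbers for weaker inhibition), compound 3 gives 115000 nM. Compound 1 `CC1(C)OC(=O)C(=CNc2cccc([N+](=O)[O-])c2)C(=O)O1` differs from it by nitro in place of 1,3-benzothiazol-2-yl on an aromatic carbon. In this assay compound 1 gives > 250000 nM, which is a limit of the assay and not a number. That change made an at least 2.1-fold higher number from compound 3 to compound 1 (0.33 log units; beyond the scatter), a move towards weaker inhibition.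

Compound 2 `CC1(C)OC(=O)C(=CNc2ccccc2-c2nc3ccccc3s2)C(=O)O1` has the same atoms as compound 3, joined differently; the difference between the two cores is not broken down here. In this assay compound 2 gives > 250000 nM, again a limit rather than a number. So far, then, (the limit of > 250000 nM in this assay, at which 2 of the 3 values shown sit).

Compound 4 `CC1(C)OC(=O)C(=CNc2ccccc2[N+](=O)[O-])C(=O)O1` has not yet been measured. It differs from compound 2 by nitro in place of 1,3-benzothiazol-2-yl on an aromatic carbon. For the measured compounds named here, this is the same kind of change as the one from compound 3 to compound 1, though not the same: there the entering nitro sits "meta to a large group", here it sits "ortho to a large group".

Going by the values given here, the expectation rests on two things: the one measured instance of this kind of change, an at least 2.1-fold higher number from compound 3 to compound 1 (0.33 log units; beyond the scatter), weakened inhibition, and compound 2 already sits at a limit. Compound 4 is therefore expected to give 300000 nM. The expected step is a step that the limit leaves unreadable from compound 2 to compound 4, with the result most likely reported once more as a limit.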

Compound 4, half-maximal inhibitory concentration: > 500000 nM
Compound 4 was reported as a limit; the forecaster's own chance of this, stated with the estimate: 85%; at least 1.6-fold (0.22 log units) between middle value and limit.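

In this assay compound 4 gives > 500000 nM, which is a limit of the assay and not a number. Compound 2 gives > 250000 nM, also a limit, so no step can be read between compound 2 and compound 4. The compounds shown leave open whether nitro in place of 1,3-benzothiazol-2-yl, ortho to a large group, changes the number at all.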